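From a lactone to a formyl group on a shared core

A few compounds are considered here, and "the series" means these few. Any claim that something is new, unique, unknown or untested is made for them only; others in the source may bear on it.

Compound 1 `C=C1CC[C@H]2C(C)(C)CCC[C@]2(C)[C@H]1C/C=C1\CC(O)OC1=O` gives 86.3% in an ADME assay on RAW264.7 cells (Mus musculus) for cytotoxicity, read by luminescence and CellTiter-Glo, with a stated time of 18 h, tested at 5 uM; on this read-out higher numbers stand for a weaker effect at the one concentration tested and lower numbers for a stronger effect. Compound 2 `C=C1CC[C@H]2C(C)(C)CCC[C@]2(C)[C@H]1C/C=C1\C=COC1=O` gives 90.8% in this assay.

Compound 2 carries the higher of the two numbers, yet the gap to compound 1 is within the scatter, so the two cannot be ordered. Compound 3 `C=C1CC[C@H]2C(C)(C)CCC[C@]2(C)[C@H]1CC=O` awaits measurement. Its change relative to compound 2 is: a group of 2 heavy atoms (1 carbon, 1 oxygen; no ring) in place of a group of 7 heavy atoms (5 carbon, 2 oxygen; one five-membered non-aromatic ring with 1 hetero atom), on a saturated chain carbon bound to a saturated ring carbon. For the measured compounds named here, no step between measured compounds is known, so the expectation for this assay rests on the structural change alone. The expected step is a number 3.8 percentage points lower from compound 2 to compound 3 (within the scatter), none beyond the scatter. Compound 3 is estimated at 87%, with a range from 72% to 100%.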

Compound 3, a percentage reported as activity, at one concentration (the size of the read-out at that concentration, not a potency): 101%
Compound 3: the middle estimate sits 14 percentage points below what was measured; the whole stated range lies below it.
By their numbers in this assay, from the lowest: compounds 1 and 2 (each within the scatter of the next); then compound 3.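

Putting formyl in place of the five-membered ring group, on a saturated chain carbon bound to a saturated ring carbon, gives a number 10.2 percentage points higher from compound 2 to compound 3 (beyond the scatter) in this assay. Compounds 1 and 2 both carry a five-membered ring here and could not show this: with the ring gone the number rises, which on this read-out means a weaker effect, so the ring is not required to keep the number high. No measurement shown explains the rise.

Going by these compounds, whether an amine, a carboxylic acid or a longer chain at this place would behave like formyl remains open. So does which part of the five-membered ring group matters, since it leaves as a whole.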